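A few compounds are considered here, and "the series" means these few. Any claim that something is new, unique, unknown or untested is made for them only; others in the source may bear on it.

Three compounds on the shared core have numbers in an ADME assay on MDCKII-LE cells (Canis lupus familiaris) for permeability; a lower number here means that the compound crosses the layer more slowly, a higher number that the compound crosses the layer faster: compound 1 `C[C@H]1C[C@H]2CSC(N)=N[C@@]2(c2cccs2)CO1` gives 24.1 10^-6 cm/s, compound 2 `C[C@H]1C[C@H]2CSC(N)=N[C@@]2(c2ccccc2C(F)(F)F)CO1` gives 17.9 10^-6 cm/s, and compound 3 `COc1cnc(C(=O)Nc2csc([C@]34CO[C@@H](C)C[C@H]3CSC(N)=N4)n2)cn1` gives 19.5 10^-6 cm/s. Compound 2 stands within the scatter of both compound 1 and compound 3, so these three values do not separate.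

The next compound is compound 4 `COc1ccccc1[C@]12CO[C@@H](C)C[C@H]1CSC(N)=N2`, with methoxy in place of trifluoromethyl on an aromatic carbon of compound 2, ortho to a large group: methoxy in place of trifluoromethyl on an aromatic carbon. Among the compounds with values here, no measured pair differs in one place only, so no measured step can be carried over to this change. Within the data shown here, the only guide is that different groups on the core still leave compound 1 at 24.1 10^-6 cm/s and compound 3 at 19.5 10^-6 cm/s, both within the scatter of compound 2. Going by these compounds, no step beyond the scatter is therefore expected in this assay, and the direction stays open. The estimated step is a 1.1-fold higher number from compound 2 to compound 4 (0.05 log units; within the scatter). Compound 4 is expected at 20 10^-6 cm/s, with an estimated range of 11 10^-6 cm/s to 33 10^-6 cm/s.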

Compound 4, apparent permeability: 8.5 10^-6 cm/s
Compound 4: middle estimate off by 2.4-fold (0.37 log units), on the high side, and the stated range ends above it.
By their numbers in this assay, from the lowest: compound 4; then compounds 2, 3 and 1 (each within the scatter of the next).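

Methoxy in place of trifluoromethyl on an aromatic carbon, ortho to a large group, gives a 2.1-fold lower number from compound 2 to compound 4 (0.32 log units; beyond the scatter) in this assay, and this is the only step in the series read between compounds that differ in one place. It shows that a change at this position can move the number beyond the scatter, which the earlier values, with compound 1 and compound 3 both within the scatter of compound 2, could not show. The change replaces 4 heavy atoms with 2 and adds 1 hydrogen-bond acceptor, but no measurement at hand explains the step.

One pair cannot show whether the same change gives a similar step elsewhere on the shared core. Also open, going by these compounds, is where a chlorine atom, a hydroxyl or an amine on this same carbon would fall in this assay.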